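The source may hold more compounds than are shown below. What is called first, only, known or untested is meant among the compounds shown, and "the series" means these compounds.

Series notes, aryl variation on the triazole nitrogen of a shared core.

In a functional assay on PANC-1 cells (Homo sapiens) for inhibition, read by MTT assay, with a stated time of 24 h (on this read-out lower numbers stand for stronger inhibition and higher numbers for weaker inhibition), compound 1 `CC1(C)[C@H]2CC[C@]1(C)N(Cc1cn(-c3cccc(Cl)c3)nn1)C(=O)C2` gives 260 nM. Compound 2 `COc1ccc(-n2cc(CN3C(=O)C[C@@H]4CC[C@@]3(C)C4(C)C)nn2)cc1`, which carries 4-methoxyphenyl in place of 3-chlorophenyl on an aromatic nitrogen, gives 330 nM in this assay; the step of a 1.3-fold higher number from compound 1 to compound 2 (0.10 log units; within the scatter) is within the scatter. Going by the values given here, compound 1 therefore has the lower of the two numbers so far, but the gap to compound 2 is too small to rank them.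

Compound 3 `CC1(C)[C@H]2CC[C@]1(C)N(Cc1cn(-c3ccc(C#N)cc3)nn1)C(=O)C2` is not yet measured in this assay. It differs from compound 1 by 4-cyanophenyl in place of 3-chlorophenyl on an aromatic nitrogen. Among the compounds with values here, the only measured step that bears on this change is the aryl swap at the same aromatic nitrogen, from compound 1 to compound 2, and that step stayed within the scatter. Within the data shown here, no step with a nitrile on the phenyl has been measured, so nothing beyond that single comparison supports the estimate. On this basis the step from compound 1 to compound 3 is expected to be a 1.2-fold higher number from compound 1 to compound 3 (0.06 log units; within the scatter), that is, no change beyond the scatter. For compound 3 the estimate in this assay is 300 nM, with a range from 150 nM to 650 nM.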

Compound 3, half-maximal inhibitory concentration: 250 nM
The estimate for compound 3 lay 1.2-fold (0.08 log units) above the measured number; measured number inside the range.
By their numbers in this assay, from the lowest: compounds 3, 1 and 2 (each within the scatter of the next).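

In this assay the step is a 1.0-fold lower number from compound 1 to compound 3 (0.02 log units; within the scatter) and so gives no ranking: 4-cyanophenyl on the aromatic nitrogen reads like 3-chlorophenyl, even though it brings a triple bond and a hydrogen-bond acceptor that 3-chlorophenyl lacks. The cyano and methoxy groups on the aromatic carbon also cannot be ranked, with a 1.3-fold lower number from compound 2 to compound 3 (0.12 log units; within the scatter) as the step between them, so this position now shows three aryl groups whose numbers all lie within the scatter of one another, and the earlier single swap has become a small set with no separation among its members. The data available offer no explanation for this flat reading.

Still open, going by these compounds, is whether the flat reading survives when the phenyl ring carries an amine or a carboxylic acid, or gives way to a plain alkyl chain or a cyclohexyl ring. Also open, on these data alone, is how much the place of the substituent matters apart from its identity, which a pair such as 3-cyanophenyl and 4-chlorophenyl would address.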